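Three Esters of Polyhydroxybenzoic Acids and a Triple Ester

The source may hold more compounds than are shown below. What is called first, only, known or untested is meant among the compounds shown, and "the series" means these compounds.

Three compounds were measured in a functional assay on NCI-H1299 cells (Homo sapiens) for inhibition, read by scintillation counting, with a stated time of 30 min, tested at 30 uM; on this read-out higher numbers stand for more inhibition at the one concentration tested (going by the name of the read-out) and lower numbers for less inhibition:

Compound 1, `O=C(Oc1cccc(F)c1OC(=O)c1cc(O)c(O)c(O)c1)c1cc(O)c(O)c(O)c1`, gave 81.1%.
Compound 2, `COc1cccc(OC(=O)c2ccccc2O)c1OC(=O)c1ccccc1O`, gave 50.5%.
Compound 3, `COc1cccc(OC(=O)c2ccc(O)cc2)c1OC(=O)c1ccc(O)cc1`, gave 86.5%.

Among these, compound 3 sits close to compound 1, the two numbers lying within the scatter of each other, while compound 2 lies well below both, beyond the scatter. Compound 3 and compound 2 share the same core carrying a methoxy and two ester groups and differ only in where the hydroxyl sits on each benzoyl part, yet their numbers in this assay are far apart.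

Compound 4, `O=C(Oc1cccc(OC(=O)c2ccc(O)cc2)c1OC(=O)c1ccc(O)cc1)c1ccc(O)cc1`, is the unmeasured compound. It carries the change ((4-hydroxyphenyl)carbonyl in place of methyl on an oxygen on an aromatic ring), so that the core of compound 3 now bears three identical ester groups instead of two esters and a methoxy.

For the measured compounds named here, no measured pair shows this kind of step, so the size of the change cannot be read from the data. Because compound 3 already gives 86.5% in this assay, there is little room for a rise, and the author expects the step of a number 1.5 percentage points lower from compound 3 to compound 4 (within the scatter) to stay within the scatter. Compound 4 is therefore estimated to give 85%, with a range from 70% to 97%.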

Compound 4, a percentage reported as inhibition, at one concentration (the size of the read-out at that concentration, not a potency): 88.7%
For compound 4 the middle estimate is 3.7 percentage points below the measured one; low and high end bracket the measured number.
By their numbers in this assay, from the lowest: compound 2; then compounds 1, 3 and 4 (each within the scatter of the next).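

For the compounds shown here, replacing methyl with (4-hydroxyphenyl)carbonyl on an oxygen on an aromatic ring gives the first one-place comparison in this set, and in this assay it produces a number 2.2 percentage points higher from compound 3 to compound 4 (within the scatter). At this position, therefore, the methoxy can give way to ((4-hydroxyphenyl)carbonyl)oxy, a group of 9 heavy atoms with its own six-membered aromatic ring, without the read-out leaving the scatter, and the core can carry three identical ester groups in place of two esters and a methoxy. No accompanying measurement bears on this result, and the step stands as an observation without an explanation.

What the compounds shown leave open is whether this position would accept something quite different on the same oxygen, such as an amine-bearing chain, a carboxylic acid or a longer alkyl chain, and whether the hydroxyl of the entering group plays any part in the result. Compound 3 and compound 4 are also compared at a single concentration only, which leaves open whether they would still lie this close on a full measure of potency.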